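Trimethoxyphenyl in place of fluorohydroxyphenyl in a limit-bound series

The source may hold more compounds than are shown below. What is called first, only, known or untested is meant among the compounds shown, and "the series" means these compounds.

Compound 2 `CN(C)CCn1cnnc1-c1cc(Oc2ccc(NC(=O)N/N=C/c3ccc(O)c(F)c3)cc2F)ccn1` carries a 3-fluoro-4-hydroxyphenyl on a carbon with a double bond to nitrogen. In a functional assay on U-87MG ATCC cells (Homo sapiens) for cytotoxicity, read by MTT assay, with a stated time of 72 h (a lower number here means a stronger inhibitor, a higher number a weaker inhibitor), compound 2 gives only a limit of the assay, > 100000 nM. Compound 1 `CN(C)CCn1cnnc1-c1cc(Oc2ccc(NC(=O)N/N=C/c3cccc(O)c3)cc2F)ccn1` likewise gives a limit, > 100000 nM. Compound 3 `COc1ccc(/C=N/NC(=O)Nc2ccc(Oc3ccnc(-c4nncn4CCN(C)C)c3)c(F)c2)cc1O` also gives a limit, > 100000 nM. The steps a step that the two limits leave unreadable from compound 1 to compound 2, a step that the two limits leave unreadable from compound 1 to compound 3 and a step that the two limits leave unreadable from compound 2 to compound 3 therefore cannot be sized, because the limit of > 100000 nM in this assay, at which 3 of the 3 values shown sit, holds every value shown. Compound 4 `COc1ccc(/C=N/NC(=O)Nc2ccc(Oc3ccnc(-c4nncn4CCN(C)C)c3)c(F)c2)c(OC)c1OC` differs from compound 2 in one place: 2,3,4-trimethoxyphenyl in place of 3-fluoro-4-hydroxyphenyl on a carbon with a double bond to nitrogen. For the measured compounds named here, no measured step gives a readable size, so no direction beyond the scatter can be expected. Compound 4 is estimated at 100000 nM, between 30000 nM and 300000 nM, most likely again reported as a limit, an expected step of a number no higher from compound 2 to compound 4 (the limit leaves the size open).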

Compound 4, half-maximal inhibitory concentration: 7650 nM
For compound 4 the middle estimate is 13-fold (1.12 log units) above the measured one; measured number outside the range, below it.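

Readable steps appear for the first time in this series: an at least 13-fold lower number from compound 2 to compound 4 (1.11 log units; beyond the scatter) and an at least 13-fold lower number from compound 3 to compound 4 (1.11 log units; beyond the scatter) and an at least 13-fold lower number from compound 1 to compound 4 (1.11 log units; beyond the scatter) all come with 2,3,4-trimethoxyphenyl on a carbon with a double bond to nitrogen, in this assay at this one place. So the group at this place can change the result, whereas the steps among compounds 1, 2 and 3 cannot be read, and the new steps stay open on one side: the limit of > 100000 nM in this assay, at which 3 of the 4 values shown sit.

Which of the three methoxy groups matters stays open. So does whether an amine or a longer chain such as ethoxy at this place would give a lower number.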